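From aryloxy linker to a directly bound pyridyl

This account rests on a few compounds, and the source may have more. Where it says the series, first, only, none or still open, it means among the compounds named here.

Compound 3 `O=C1C(=O)N(Cc2ccc(Oc3ccccn3)cc2)c2ccc(OC(F)(F)F)cc21` is the lowest of the two numbers in a functional assay on CHO cells for positive allosteric modulation of muscarinic acetylcholine receptor M5 (Homo sapiens), read by FLIPR and calcium flux, with a stated time of 1 h (on this read-out lower numbers stand for smaller maximal responses and higher numbers for larger maximal responses), where compound 3 gives 46%. Compound 2 `O=C1C(=O)N(Cc2ccc(Oc3nccs3)cc2)c2ccc(OC(F)(F)F)cc21` gives 58% in this assay, and the step of a number 12 percentage points lower from compound 2 to compound 3 (beyond the scatter) lies beyond the scatter. Compound 1 `O=C1C(=O)N(Cc2ccc(-c3ccccc3)cc2)c2ccc(OC(F)(F)F)cc21` gives only a limit in this assay, < 60%. Compound 4 `O=C1C(=O)N(Cc2ccc(-c3ccncc3)cc2)c2ccc(OC(F)(F)F)cc21` differs from compound 3 as follows: pyridin-4-yl in place of (pyridin-2-yl)oxy on an aromatic carbon. Among the compounds with values here, no measured step swaps an aryloxy group for a directly bound ring, and the steps a step that the limit leaves unreadable from compound 1 to compound 2 and a step that the limit leaves unreadable from compound 1 to compound 3 leave the size of such a swap unreadable, as does (the limit of < 60% in this assay, at which 1 of the 3 values shown sits). Compound 4 is therefore expected to give about 50%, with a range from 35% to 65%. The expected step of a number 4 percentage points higher from compound 3 to compound 4 (within the scatter) is not expected to exceed the scatter.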

Compound 4, largest response reached (Emax), in percent of the reference or control that the assay uses: 60%
Compound 4: middle estimate off by 10 percentage points, on the low side; the range from low to high includes it.
By their numbers in this assay, from the lowest: compound 3; then compounds 2 and 4 (each within the scatter of the next).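

Within the data shown here, on the aromatic carbon para to a large group, pyridin-4-yl gives the first readable comparison between a directly bound ring and the aryloxy groups in this assay. Pyridin-4-yl in place of (pyridin-2-yl)oxy gives a number 14 percentage points higher from compound 3 to compound 4 (beyond the scatter). Pyridin-4-yl in place of (1,3-thiazol-2-yl)oxy gives a number 2 percentage points higher from compound 2 to compound 4 (within the scatter), so the directly bound ring is not set apart from both aryloxy groups. Pyridin-4-yl in place of the phenyl group gives a number no lower from compound 1 to compound 4 (the limit leaves the size open), a step whose size cannot be read: the limit of < 60% in this assay, at which 1 of the 4 values shown sits.

Still open, as far as these compounds go, is what a directly bound pyridin-2-yl would give, which would separate the ring from the oxygen linker. Also open, from the compounds shown here alone, is how an amine or a carboxylic acid on this ring would read in this assay.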